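Amide to urea on the benzothiazole-free core: compound 4 expected

The source may hold more compounds than are shown below. What is called first, only, known or untested is meant among the compounds shown, and "the series" means these compounds.

Of the compounds shown here, three sharing one core have been measured in a functional assay on HCT-116 cells (Homo sapiens) for inhibition, read by MTT assay, with a stated time of 2 days, tested at 10 uM; on this read-out lower numbers stand for less inhibition of growth and higher numbers for more inhibition of growth at the one concentration tested. Compound 1 `CNC(=O)c1cc(Oc2ccc3nc(NC(=O)Nc4cc(C(F)(F)F)cc(C(F)(F)F)c4)sc3c2)ccn1` gives 87.5% in this assay, compound 3 `CNC(=O)c1cc(Oc2ccc3nc(NC(=O)Nc4ccc(C5CCN(C(C)C)CC5)cc4)sc3c2)ccn1` gives 68.1%, and compound 2 `CNC(=O)c1cc(Oc2ccc3nc(NC(=O)c4ccc(Cl)cc4)sc3c2)ccn1` gives 27.5%. Compound 2 thus stands lowest of the three: compound 3 lies above it by a margin beyond the usual scatter, and compound 1 lies further above still, also beyond the scatter.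

The unmeasured compound 4 `CNC(=O)c1cc(Oc2ccc3nc(NC(=O)Nc4ccc(Cl)cc4Cl)sc3c2)ccn1` differs from compound 2 in one place: (2,4-dichlorophenyl)amino in place of 4-chlorophenyl on a carbonyl carbon. Among the compounds with values here, no directly measured pair separated by a single change of this kind is available, so the size of the step must be judged from the surrounding compounds. Compound 1 and compound 3, which like compound 4 carry an amino-linked aryl group on that carbonyl carbon, both sit well above compound 2: compound 1 gives 87.5%, compound 3 gives 68.1%, and compound 2 gives 27.5%.

On that basis the step of a number 42.5 percentage points higher from compound 2 to compound 4 (beyond the scatter) is expected to be upward and beyond the scatter. Compound 4 is therefore estimated at 70% in this assay, within a range of 45% to 90%.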

Compound 4, percent growth inhibition at one concentration: 32.2%
For compound 4 the middle estimate is 37.8 percentage points above the measured one; measured number below the stated range.
By their numbers in this assay, from the lowest: compounds 2 and 4 (each within the scatter of the next); then compound 3; then compound 1.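

In this assay the exchange of 4-chlorophenyl for (2,4-dichlorophenyl)amino on a carbonyl carbon whose other neighbour is an amide-type nitrogen gives a number 4.7 percentage points higher from compound 2 to compound 4 (within the scatter), so this change, which brings one hydrogen-bond donor and a second chlorine, does not separate the two compounds at this position. An amino-linked aryl group on this carbonyl carbon is therefore not enough on its own for a high number: compound 3 at 68.1% and compound 1 at 87.5% carry such a group, but so does compound 4 at 32.2%, and the values follow the aryl group attached to the amino link rather than the link alone. Nothing at hand offers a measured explanation for this result.

The step combines the amino link with the second chlorine, so it cannot show whether each has no effect on its own or whether their effects offset one another. As far as these compounds go, a (4-chlorophenyl)amino group or a 2,4-dichlorophenyl group on the same carbonyl carbon would separate the two parts, and both remain open here.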